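The source may report more compounds than this note shows. Statements on the series, on what has been measured and on what is new or still open speak of the compounds shown alone.

Measured in a functional assay on PC-3 cells (Homo sapiens) for antiproliferative activity, read by MTT assay, with a stated time of 72 h; a higher number here means a weaker inhibitor, a lower number a stronger inhibitor:

Compound 1 `CC/C=C/C(=O)Nc1cc2c(N3CCc4ccccc43)ncnc2cc1OC` gives 5890 nM.
Compound 2 `CC/C=C/C(=O)Nc1cc2c(N3CCc4ccccc43)ncnc2cc1O[C@@H]1CCOC1` gives 9590 nM.
Compound 3 `COc1cc2ncnc(N3CCCc4ccccc43)c2cc1NC(=O)/C=C/CN(C)C` gives 1750 nM.

Compound 3 stands lowest of the three in this assay, with compound 1 the nearest of the other two and compound 2 the furthest; both gaps lie beyond the scatter. The change from compound 1 to compound 2 is oxolan-3-yl in place of methyl on an oxygen on an aromatic ring, and it made a step of a 1.6-fold higher number from compound 1 to compound 2 (0.21 log units; within the scatter), a step that stays within the scatter.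

Compound 4 `CN(C)C/C=C/C(=O)Nc1cc2c(N3CCCc4ccccc43)ncnc2cc1O[C@@H]1CCOC1` is not yet measured in this assay. It arises from compound 3 by oxolan-3-yl in place of methyl on an oxygen on an aromatic ring, the same change as that from compound 1 to compound 2, made at the same place. The difference between the core of compound 3 and the core of compound 1 is not broken down here.

Among the measured compounds shown here, the only guide for compound 4 is the single earlier instance of this change. Compound 4 is therefore expected to sit close to compound 3, with a step of about a 1.6-fold higher number from compound 3 to compound 4 (0.20 log units; within the scatter) in this assay, which rests on the step of a 1.6-fold higher number from compound 1 to compound 2 (0.21 log units; within the scatter) seen in the first pair. On that basis the estimate for compound 4 in this assay is 2800 nM, with a range from 1200 nM to 6500 nM, the width of the range allowing for the change being carried onto a core where it has not been seen before.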

Compound 4, half-maximal inhibitory concentration: 4170 nM
Compound 4: middle estimate off by 1.5-fold (0.17 log units), on the low side; the range from low to high includes it.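

In this assay, oxolan-3-yl in place of methyl on an oxygen on an aromatic ring gives a 2.4-fold higher number from compound 3 to compound 4 (0.38 log units; beyond the scatter) on the core of compound 3, so the number moves in the same direction on both cores shown, although only this step lies beyond the scatter. This does not establish a general rule for the series: it rests on two pairs and one replacement, the two pairs also differ in the amide chain as well as in the core, and no cause for the shift can be drawn from these data. Within those limits, the size of the step carries from one core to the other, and the two instances cannot be told apart: the same change on two cores in this assay, a 1.6-fold higher number (0.21 log units; within the scatter) from compound 1 to compound 2 and a 2.4-fold higher number (0.38 log units; beyond the scatter) from compound 3 to compound 4, 1.5-fold (0.17 log units) apart, within the scatter of two such steps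

The compounds shown leave open whether the same step would hold on the oxygen for a longer ether chain such as methoxyethyl, or for a propyl chain ending in an amine such as morpholine. They also leave open how the opposite configuration at the oxolan-3-yl stereocentre would read out, and whether the step would persist on cores beyond these two.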